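This account rests on a few compounds, and the source may have more. Where it says the series, first, only, none or still open, it means among the compounds named here.

Series notes. Going by the values given here, in a functional assay on L1210 cells (Mus musculus) for antiproliferative activity, read by MTT assay, with a stated time of 2 days (on this read-out higher numbers stand for weaker inhibition and lower numbers for stronger inhibition), compound 1 `CCCCCCC#Cc1cn(C/C=C/CN2C(=O)c3ccccc3C2=O)c(=O)[nH]c1=O` gives 43000 nM, the second highest of the three numbers measured so far. Compound 3 `CCCCCc1ccc(C#Cc2cn(C/C=C\CN3C(=O)c4ccccc4C3=O)c(=O)[nH]c2=O)cc1` gives 28000 nM, within the scatter of compound 1, while compound 2 `O=C1c2ccccc2C(=O)N1C/C=C\Cn1cc(C#CCCc2ccccc2)c(=O)[nH]c1=O` gives 143000 nM, beyond the scatter. Among the compounds with values here, the only single-point step recorded is a 5.1-fold lower number from compound 2 to compound 3 (0.71 log units; beyond the scatter), a swap of the group on a triple-bonded carbon rather than an extension of a saturated chain, so it does not bear directly on compound 4 `CCCCCCCCC#Cc1cn(C/C=C/CN2C(=O)c3ccccc3C2=O)c(=O)[nH]c1=O`. Compound 4 differs from compound 1 by ethyl in place of hydrogen on a saturated chain carbon, six bonds along the chain from a triple-bonded carbon. Within the data shown here, no measured step of this kind exists in the set, so no change beyond the scatter is expected in this assay. The step is estimated as a 1.3-fold lower number from compound 1 to compound 4 (0.13 log units; within the scatter). Compound 4 is expected to give about 32000 nM, with a range of 12000 nM to 85000 nM.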

Compound 4, half-maximal inhibitory concentration: > 250000 nM
Compound 4 was reported as a limit (the forecaster's own chance of this, stated with the estimate: 5%); at least 7.8-fold (0.89 log units) between middle value and limit.
By their numbers in this assay, from the lowest: compounds 3 and 1 (each within the scatter of the next); then compound 2. At a limit, above all of these: compound 4.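

In this assay, the saturated chain carbon six bonds along the chain from a triple-bonded carbon is sensitive to substitution: ethyl in place of hydrogen there gives an at least 5.8-fold higher number from compound 1 to compound 4 (0.76 log units; beyond the scatter). Going by these compounds alone, this is the first step in the set made on a saturated chain, and it moves the read-out towards weaker inhibition. Compound 4 stands at a limit of the assay, not at a number: the limit of > 250000 nM in this assay, at which 1 of the 4 values shown sits.

Going by these compounds, the full size of this step stays open, as does whether methyl at this place would already raise the number. Also open, on these data alone, is whether an amine there would behave as ethyl does.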